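Exchanging One Ring on Compound 2

The source may hold more compounds than are shown below. What is called first, only, known or untested is meant among the compounds shown, and "the series" means these compounds.

Measured so far in an ADME assay on the whole organism (Mus musculus, strain CD-1) for pharmacokinetics, at a dose of 10 mg/kg by the oral route; a higher number here means that a larger share of the oral dose reaches the circulation, a lower number that a smaller share of the oral dose reaches the circulation:
- compound 1 `COc1cc([C@](O)(CCN(C)C)[C@@H](c2cc3cc(Br)ccc3nc2OC)c2ccnc(OC)c2OC)cc(OC(C)C)n1`: 22%
- compound 2 `COc1cc([C@](O)(CCN(C)C)[C@@H](c2cc3cc(Br)ccc3nc2OC)c2cccc(OC)c2F)cc(OC(F)F)n1`: 83%

Of these two, compound 2 stands highest at 83%, and the gap down to compound 1 lies beyond the scatter. Compound 3 `COc1cc([C@](O)(CCN(C)C)[C@@H](c2cc3cc(Br)ccc3nc2OC)c2ccnc(OC)c2OC)cc(OC(F)F)n1` has not yet been measured. It differs from compound 2 in one place: 2,3-dimethoxypyridin-4-yl in place of 2-fluoro-3-methoxyphenyl on a saturated chain carbon bound to an aromatic carbon and a saturated chain carbon. Here, 2,3-dimethoxypyridin-4-yl takes the place of 2-fluoro-3-methoxyphenyl on a saturated chain carbon bound to an aromatic carbon and a saturated chain carbon. For the measured compounds named here, compound 1 also carries the entering group and gives 22%, but it differs from compound 2 in more than one place, so no measured step isolates this change. A moderate drop beyond the scatter is therefore expected in this assay. The expected step is a number 33 percentage points lower from compound 2 to compound 3 (beyond the scatter). For compound 3 the estimated value is 50%, with a range of 25% to 75%.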

Compound 3, oral bioavailability: 50%
Compound 3: the middle estimate sits on the measured number at the digits printed, and the stated range covers the measured number.
By their numbers in this assay, from the lowest: compound 1; then compound 3; then compound 2.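

For the compounds shown here, compound 3 gives the first comparisons in this assay that change only one place at a time. With the rest of the structure held fixed, placing 2,3-dimethoxypyridin-4-yl in place of 2-fluoro-3-methoxyphenyl on the saturated chain carbon gives a number 33 percentage points lower from compound 2 to compound 3 (beyond the scatter) on its own. With 2,3-dimethoxypyridin-4-yl kept, difluoromethyl in place of isopropyl on an oxygen on an aromatic ring gives a number 28 percentage points higher from compound 1 to compound 3 (beyond the scatter) and so shows that this second place also moves the oral bioavailability beyond the scatter.

The ring exchange alters several things at once, and a 2-fluoro-3-methoxypyridin-4-yl ring would help separate the ring nitrogen, the fluorine and the second methoxy group. Nothing measured in this set explains why either change moves the number.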